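A few compounds are considered here, and "the series" means these few. Any claim that something is new, unique, unknown or untested is made for them only; others in the source may bear on it.

Measured in an ADME assay on BJ cells (Homo sapiens) for cytotoxicity, with a stated time of 72 h; a higher number here means that more compound is needed for the effect, a lower number that less compound is needed:
- compound 1 `Cc1ccc(-c2nc3ccccc3s2)cc1NC(=O)c1cc([N+](=O)[O-])c(N(C)C)cc1Cl`: > 25000 nM
- compound 2 `COc1ccc(-c2nc3ccccc3o2)cc1NC(=O)c1cc([N+](=O)[O-])ccc1Cl`: > 25000 nM
- compound 3 `O=C(Nc1cccc(-c2ccccc2)c1)c1cc([N+](=O)[O-])ccc1Cl`: > 27000 nM

None of these three entries is a number; each is a limit of this assay. Compound 1 stands at the limit > 25000 nM, and it shares this position with one other compound: the limit of > 25000 nM in this assay, at which 2 of the 3 values shown sit.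

Compound 4 `Cc1ccc(-c2nc3ccccc3s2)cc1NC(=O)c1cc([N+](=O)[O-])ccc1Cl` has not yet been measured. It departs from compound 1 in one place: hydrogen in place of dimethylamino on an aromatic carbon. The change puts hydrogen in place of dimethylamino on an aromatic carbon, ortho to a nitro group.

Going by the values given here, no step between measured compounds is available to size this change, so the expectation rests on the limits alone. Compound 2 also carries hydrogen on that carbon, and its entry is the limit > 25000 nM. Compound 3 carries hydrogen there too, and its entry is the limit > 27000 nM. The expected step of a number no higher from compound 1 to compound 4 (the limit leaves the size open) is therefore estimated to be none beyond the scatter. Compound 4 is estimated at 25000 nM, with an expected range of 10000 nM to 50000 nM.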

Compound 4, half-maximal effective concentration: > 14000 nM
Compound 4: a limit, no number; the forecaster's own chance of this, stated with the estimate: 80%; the middle value lies beyond the limit too.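

Going by these compounds alone, compound 1 and compound 4 both stand as limits in this assay, and no step between them can be read. The compounds shown leave open what number any of them would reach, and whether hydrogen in place of dimethylamino on an aromatic carbon shifts it at all.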